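This account rests on a few compounds, and the source may have more. Where it says the series, first, only, none or still open, it means among the compounds named here.

Measured in an ADME assay on BHK-21 cells (Mesocricetus auratus) for cytotoxicity, read by MTT assay, with a stated time of 96 h; a higher number here means that more compound is tolerated, a lower number that less compound is tolerated:
- Compound 1 `CN1CCN(/N=N/c2ccccc2)CC1`: 70000 nM
- Compound 2 `c1ccc(/N=N/N2CCN(c3ncccn3)CC2)cc1`: > 100000 nM

The entry for compound 2 is a limit of the assay and not a number. Its exact place on the scale is therefore unknown, and (the limit of > 100000 nM in this assay, at which 1 of the 2 values shown sits).

Compound 3 `CCOC(=O)N1CCN(/N=N/c2ccccc2)CC1` has not yet been measured. It differs from compound 2 by one change: ethoxycarbonyl in place of pyrimidin-2-yl on an amine nitrogen in a ring. In words, ethoxycarbonyl stands in place of pyrimidin-2-yl on an amine nitrogen in a ring.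

Among the measured compounds shown here, only one measured step bears on this change, since it alters the same place on the shared core: an at least 1.4-fold higher number from compound 1 to compound 2 (0.15 log units; that floor lies within the scatter). That is thin evidence, and ethoxycarbonyl itself has not been tested on this core. Even so, the step from compound 1 to compound 2 gives no reason to expect a large shift in this assay, in either direction. The expected result is a number no higher from compound 2 to compound 3 (the limit leaves the size open), with no change beyond the scatter anticipated. For compound 3 the estimated value is 100000 nM, with an expected range of 45000 nM to 220000 nM.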

Compound 3, half-maximal cytotoxic concentration: > 100000 nM
Compound 3: no number, only a limit (the forecaster's own chance of this, stated with the estimate: 50%); the middle value sits exactly at the limit.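

In this assay compound 3 gives > 100000 nM, which is a limit of the assay and not a number. The step from pyrimidin-2-yl to ethoxycarbonyl cannot be read, because both compounds rest at the same limit: the limit of > 100000 nM in this assay, at which 2 of the 3 values shown sit.

Replacing methyl with ethoxycarbonyl on the amine nitrogen in a ring gives an at least 1.4-fold higher number from compound 1 to compound 3 (0.15 log units; that floor lies within the scatter), so this position has now carried a group with no ring as well as an aromatic ring without either result falling under the limit, although neither group can be ranked against the other or clearly separated from methyl.

As far as these compounds go, how far compound 2 and compound 3 actually lie beyond the limit remains unknown, so any real difference between them stays hidden. From the compounds shown here alone, it is also open whether a carboxylic acid, a primary amine or a longer chain on that same nitrogen would stay at the limit or would bring the tolerated concentration down to a measurable number.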